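The source may hold more compounds than are shown below. What is called first, only, known or untested is meant among the compounds shown, and "the series" means these compounds.

Working notes on the series. In a functional assay on HeLa cells (Homo sapiens) for inhibition (a higher number here means a weaker inhibitor, a lower number a stronger inhibitor), compound 1 `COc1cc2ccc(CCc3ccc4ccccc4c3)cc2cc1O` gives 3590 nM. Compound 2 `COc1cc(/C=C/c2ccc(N(C)C)c([N+](=O)[O-])c2)cc(OC)c1OC` stands at > 5000 nM, which is a limit of the assay and not a number. No exact value is therefore available for compound 2, and any step from it is counted from that limit.

Compound 3 `COc1cc(/C=C\c2ccc(N(C)C)c([N+](=O)[O-])c2)cc(OC)c1OC` changes configuration only: the two compounds have the same atoms and bonds and differ only in configuration as drawn: 1 of 1 stereo elements differ; a double bond is drawn E in compound 2 and Z in compound 3. Nothing leaves and nothing enters. For the measured compounds named here, the series holds no measured pair that shows what such a change does, so the expectation rests on the structural change alone and stays wide.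

A large move toward stronger inhibition is expected, well beyond the usual scatter, and the estimated step is an at least 33-fold lower number from compound 2 to compound 3 (1.52 log units; beyond the scatter). For compound 3 the expected value is 150 nM, with an estimated range from 15 nM to 3000 nM.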

Compound 3, half-maximal inhibitory concentration: > 5000 nM
Compound 3 ended at the assay's limit (the forecaster's own chance of this, stated with the estimate: 10%); middle value at least 33-fold (1.52 log units) from the limit.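

In this assay no step can be read from compound 2 to compound 3, since the values of compound 2 and compound 3 are both limits of the assay and not numbers. The compounds shown leave open whether the double bond drawn E or Z gives the stronger inhibition.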